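Series notes: cinnamamide aryl swap, compound 3 to compound 4

The source may hold more compounds than are shown below. What is called first, only, known or untested is meant among the compounds shown, and "the series" means these compounds.

Measured so far:
compound 1 `COc1cc(/C=C/C(=O)Nc2cc(C(=O)c3cc(OC)c(OC)c(OC)c3)ccc2OC)ccc1F`, 7700 nM
compound 2 `COc1ccc(C(=O)c2cc(OC)c(OC)c(OC)c2)cc1NC(=O)/C=C/c1cccc(OC(F)(F)F)c1`, 5200 nM
compound 3 `COc1ccc(/C=C/C(=O)Nc2cc(C(=O)c3cc(OC)c(OC)c(OC)c3)cc(OC)c2OC)cc1OC`, 2300 nM

All three compounds were read in a functional assay on HT-29 cells (Homo sapiens) for cytotoxicity, read by MTT assay, with a stated time of 72 h; on this read-out higher numbers stand for weaker inhibition and lower numbers for stronger inhibition. Compound 3 gives the lowest number of the three; compound 2 and compound 1 both stand above it, each beyond the scatter, so compound 3 is the strongest of the measured set. Compound 1 and compound 2 differ in the aryl on the double-bonded chain carbon and give a 1.5-fold lower number from compound 1 to compound 2 (0.17 log units; within the scatter), a step of no consequence. Compound 2 and compound 3 differ in more than one place, so their values are only compared, not taken as a step.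

Compound 4 `C#CCOc1cccc(/C=C/C(=O)Nc2cc(C(=O)c3cc(OC)c(OC)c(OC)c3)cc(OC)c2OC)c1` is not yet measured. It differs from compound 3 by 3-(propargyloxy)phenyl in place of 3,4-dimethoxyphenyl on a double-bonded chain carbon bound to a double-bonded chain carbon. Among the measured compounds shown here, the one measured step at this place, from compound 1 to compound 2, was within the scatter, though it exchanged two aryls unlike those here. For the measured compounds named here, no measured step covers the loss of a methoxy pair for a propargyloxy. The expectation for compound 4 is therefore a small step in this assay, if any, estimated as a 1.7-fold higher number from compound 3 to compound 4 (0.24 log units; within the scatter). Compound 4 is expected to give 4000 nM, with a range of 1500 nM to 12000 nM.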

Compound 4, half-maximal inhibitory concentration: 8100 nM
Beside the measured number, compound 4's estimate is 2.0-fold (0.31 log units) below it; measured number inside the range.
By their numbers in this assay, from the lowest: compound 3; then compounds 2, 1 and 4 (each within the scatter of the next).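

In this assay, among the compounds shown here, the aryl on a double-bonded chain carbon bound to a double-bonded chain carbon now gives a step that counts: 3-(propargyloxy)phenyl in place of 3,4-dimethoxyphenyl gives a 3.5-fold higher number from compound 3 to compound 4 (0.55 log units; beyond the scatter) and stands beyond the scatter, while the only earlier step at this place, a 1.5-fold lower number from compound 1 to compound 2 (0.17 log units; within the scatter), stayed within it. This position is therefore not indifferent to its aryl, at least on the core shared by compound 3 and compound 4. The heavy-atom count stays the same across the change, while one hydrogen-bond acceptor leaves and a triple bond outside aromatic rings enters, and nothing at hand ties the step to either difference.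

The compounds shown leave open whether the step follows from the 3,4-dimethoxyphenyl leaving or from the propargyloxy entering, which a plain 3-methoxyphenyl at this place would help to separate. Also open, as far as these compounds go, are how an amine or a carboxylic acid on this aryl would read in this assay and whether the same swap gives a similar step on the core of compound 1.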